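Working notes on the next step in the series

A few compounds are considered here, and "the series" means these few. Any claim that something is new, unique, unknown or untested is made for them only; others in the source may bear on it.

Compound 1 `O=C1NC(=O)/C(=C/c2ccc(OCc3csc(-c4ccccc4)n3)cc2)S1` and compound 2 `O=C1NC(=O)/C(=C/c2ccc(OCCSc3nnc(Cc4ccccc4)[nH]3)cc2)S1` share a core and differ in the side chain. In a functional assay on the whole organism (strain Wistar) with Rattus norvegicus as the target, with a stated time of 15 days, at a dose of 3 mg/kg by the oral route (a higher number here means a stronger effect of the compound at the dose given, a lower number a weaker effect), compound 1 gives 25.2%. In this assay compound 2 gives 22.5%; the two values lie within the scatter of each other, so neither is separated from the other on the numbers shown. Compound 3 `O=C1NC(=O)/C(=C/c2ccc(OCCSc3nnc(-c4ccc([N+](=O)[O-])cc4)[nH]3)cc2)S1` has not yet been measured. From compound 2 to compound 3 the change is 4-nitrophenyl in place of benzyl on an aromatic carbon. For the measured compounds named here, no measured pair in this set isolates such a change, so the data give no anchor for its size. The step of a number 1.5 percentage points higher from compound 2 to compound 3 (within the scatter) is expected to remain within the scatter. Compound 3 is expected to give 24%, in a range from 10% to 40%.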

Compound 3, a percentage reported as activity, at one dose (the size of the read-out at that dose, not a potency): 14.1%
The estimate for compound 3 lay 9.9 percentage points above the measured number, and the stated range covers the measured number.
By their numbers in this assay, from the lowest: compounds 3, 2 and 1 (each within the scatter of the next, the first and the last beyond it).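

In this assay, 4-nitrophenyl in place of benzyl on the aromatic carbon between two ring nitrogen atoms gives a number 8.4 percentage points lower from compound 2 to compound 3 (within the scatter). For the compounds shown here, this is the first reading at this position, and it shows that this exchange, with an aryl group of 9 heavy atoms replacing one of 7, does not produce a step beyond the scatter. Nothing available bears on a cause for this step.

The compounds shown leave open whether the nitro group or the change from benzyl to an aryl group matters more at this position, which unsubstituted phenyl on the same carbon would separate. From the compounds shown here alone, the reading of an amine or a carboxylic acid on this carbon also remains open.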